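The compounds below may be only part of what the source reports. "The series", "measured", "known", "first", "only" and "open" are said of these compounds alone.

For the measured compounds named here, compound 2 `Cc1cc(=O)n(-c2ccccc2OC(F)(F)F)nc1C(=O)Nc1ccc(Oc2ncnc3ccsc23)c(F)c1` gives 11500 nM in a functional assay on MCF7 cells (Homo sapiens) for cytotoxicity, read by MTT assay, with a stated time of 72 h (a lower number here means a stronger inhibitor, a higher number a weaker inhibitor), the highest of the two numbers so far, while compound 1 `Cc1cc(=O)n(-c2ccc(Br)cc2F)nc1C(=O)Nc1ccc(Oc2ncnc3ccsc23)c(F)c1` gives 1550 nM. Going by the values given here, the one measured step, a 7.4-fold higher number from compound 1 to compound 2 (0.87 log units; beyond the scatter), moved the number upward. Compound 3 `Cc1cc(=O)n(-c2ccc(F)cc2)nc1C(=O)Nc1ccc(Oc2ncnc3ccsc23)c(F)c1` carries a 4-fluorophenyl in place of the 2-(trifluoromethoxy)phenyl (4-fluorophenyl in place of 2-(trifluoromethoxy)phenyl on an aromatic nitrogen), returning to a fluorine-bearing phenyl as in compound 1. Among the compounds with values here, a downward step of roughly that size is therefore expected, a 4.6-fold lower number from compound 2 to compound 3 (0.66 log units; beyond the scatter), though the single step gives only a rough guide. Compound 3 is expected to give about 2500 nM in this assay, within 800 nM to 8000 nM.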

Compound 3, half-maximal inhibitory concentration: 740 nM
Compound 3: middle estimate off by 3.4-fold (0.53 log units), on the high side; measured number below the stated range.
By their numbers in this assay, from the lowest: compound 3; then compound 1; then compound 2.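

In this assay the group on the aromatic nitrogen has a large effect on the number, with a 16-fold lower number from compound 2 to compound 3 (1.19 log units; beyond the scatter) in a single change. The 4-fluorophenyl also improves on the 4-bromo-2-fluorophenyl, with a 2.1-fold lower number from compound 1 to compound 3 (0.32 log units; beyond the scatter), so the bromine and the second fluorine are not required for the lower number. Nothing measured here gives a reason for either shift.

From the compounds shown here alone, it remains open how an amine or a carboxylic acid would compare in place of the fluorine of the 4-fluorophenyl. A plain unsubstituted phenyl is also untested among the compounds shown.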